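The source may hold more compounds than are shown below. What is called first, only, known or untested is meant among the compounds shown, and "the series" means these compounds.

Compound 1, `CCOC(=O)c1cnc2n(c1=O)C(C)CC/C2=N\Nc1cccc(C(=O)O)c1`: 100 umol/kg
Compound 2, `C[C@H]1CCC(=NNc2ccccc2)c2ncc(C(=O)O)c(=O)n21`: 0.3 umol/kg; 54.8 umol/kg (2 entries)
Compound 3, `CC1CC/C(=N\Nc2ccc(Cl)cc2)c2ncc(C(=O)O)c(=O)n21`: 0.5 umol/kg

In a functional assay on the whole organism for inhibition, with Rattus norvegicus as the target (on this read-out lower numbers stand for an effect already at smaller amounts and higher numbers for an effect only at larger amounts of compound), compound 3 stands at the lowest of the two single numbers. Its nearest neighbour, compound 1, sits a long way higher, a gap well beyond the usual scatter. Compound 2 brings several entries, (the several entries of compound 2 in this assay, 0.3 umol/kg; 54.8 umol/kg (2 entries)), which do not settle into one number and so give no firm place on the scale.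

Compound 4 is `CC1CC/C(=N\Nc2ccc(O)cc2)c2ncc(C(=O)O)c(=O)n21`, still to be measured in this assay. It differs from compound 3 in one place: hydroxy in place of chloro on an aromatic carbon. The chloro leaves and a hydroxy enters, on the aromatic carbon para to a large group. Within the data shown here, no step between two measured compounds covers this exchange, so the expectation rests on the structures alone. A modest weakening is expected, a 4.0-fold higher number from compound 3 to compound 4 (0.60 log units; beyond the scatter), probably beyond the scatter but far short of the distance to compound 1. For compound 4 the expected value in this assay is 2 umol/kg, with a range from 0.4 umol/kg to 15 umol/kg.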

Compound 4, dose for 50% inhibition: 1.7 umol/kg
Estimate against measurement, compound 4: 1.2-fold (0.07 log units) above; low and high end bracket the measured number.
By their numbers in this assay, from the lowest: compound 3; then compound 4; then compound 1.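

In this assay, among these compounds, putting hydroxy in place of chloro on the aromatic carbon para to a large group gives a 3.4-fold higher number from compound 3 to compound 4 (0.53 log units; beyond the scatter), a modest step and the first reading of any change at this position. The exchange adds a hydrogen-bond donor and a hydrogen-bond acceptor where chloro has neither, and it costs some effect without removing it, since compound 4 still acts at 1.7 umol/kg. Nothing measured here says why the number moves.

Going by these compounds, whether an amine or a methoxy group on the same carbon would fall closer to compound 3 or to compound 4 remains open. Compound 2, which carries no substituent on that ring, offers no firm point of reference for either compound: the several entries of compound 2 in this assay, 0.3 umol/kg; 54.8 umol/kg (2 entries)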